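The source may hold more compounds than are shown below. What is called first, only, known or untested is meant among the compounds shown, and "the series" means these compounds.

Measured in a functional assay on Bel-7402 cells (Homo sapiens) for antiproliferative activity, read by MTT assay, with a stated time of 48 h; a higher number here means a weaker inhibitor of growth, a lower number a stronger inhibitor of growth:
- Compound 1 `COc1ccc(/C=C2\Cc3c(cc(OC)c(OC)c3OC)C2=O)cc1O`: 307 nM
- Compound 2 `COc1cc2c(c(OC)c1OC)C/C(=C\c1cc(OC)c(OC)c(OC)c1OC)C2=O`: > 10000 nM (a limit)
- Compound 3 `COc1ccc(/C=C2\Cc3cc(OC)c(OC)c(OC)c3C2=O)cc1[N+](=O)[O-]`: > 10000 nM (a limit)

Compound 3 gives > 10000 nM, which is a limit and not a number. It therefore stands at the limit of > 10000 nM in this assay, at which 2 of the 3 values shown sit.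

Compound 4 `COc1ccc(/C=C2\Cc3cc(OC)c(OC)c(OC)c3C2=O)cc1N` carries amino in place of nitro on an aromatic carbon, ortho to a methoxy group: amino in place of nitro on an aromatic carbon.

Compound 1 gives 307 nM, so a measurable value is possible among these compounds. A step towards stronger growth inhibition in this assay is therefore expected, though its size is uncertain and the result could remain at the limit. The estimated step is an at least 6.6-fold lower number from compound 3 to compound 4 (0.82 log units; beyond the scatter). For compound 4 the expected value is 1500 nM, with an estimated range from 150 nM to 10000 nM.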

Compound 4, concentration for 50% growth inhibition: > 10000 nM
Compound 4: no number, only a limit; the forecaster's own chance of this, stated with the estimate: 30%; at least 6.6-fold (0.82 log units) between middle value and limit.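

Compound 3 and compound 4 both give a limit and not a number, so no step between them can be read: the limit of > 10000 nM in this assay, at which 3 of the 4 values shown sit.

The compounds shown leave open whether amino in place of nitro changes growth inhibition at all.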